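Swapping the Aryl Group on the Amide-Type Nitrogen

This account rests on a few compounds, and the source may have more. Where it says the series, first, only, none or still open, it means among the compounds named here.

Of the compounds shown here, three built on one shared core have been tested in a functional assay on HL-60 cells (Homo sapiens) for antiproliferative activity, read by sulforhodamine B assay, with a stated time of 72 h; on this read-out lower numbers stand for stronger inhibition and higher numbers for weaker inhibition. Compound 1, `COc1ccc(C)cc1NC(=S)N/N=C/c1ccc2ccccc2n1`, reaches only the limit of that measurement, giving > 100000 nM; (the limit of > 100000 nM in this assay, at which 1 of the 3 values shown sits). Compound 2, `COc1cccc(NC(=S)N/N=C/c2ccc3ccccc3n2)c1`, gives 71200 nM in this assay, and compound 3, `CC(C)c1cccc(C(C)C)c1NC(=S)N/N=C/c1ccc2ccccc2n1`, gives 19500 nM. Of the two actual numbers, compound 2 holds the higher one and is therefore the weaker of the pair, with compound 3 sitting a step beyond the usual scatter below it.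

The untested compound 4, `S=C(N/N=C/c1ccc2ccccc2n1)Nc1ccc(Cl)cc1`, differs from compound 2 in a single place: 4-chlorophenyl in place of 3-methoxyphenyl on an amide-type nitrogen. A group carrying one hydrogen-bond acceptor leaves and a group carrying none enters, on an amide-type nitrogen whose other neighbour is the thiocarbonyl carbon.

Within the data shown here, no measured pair shows what this particular swap does, so the expectation rests only on the spread seen so far, where changing the ring on this nitrogen moved the numbers of compound 2 and compound 3 apart by more than the scatter. Compound 4 is expected to give about 35000 nM in this assay, with a likely range from 6000 nM to 150000 nM. The step of a 2.0-fold lower number from compound 2 to compound 4 (0.31 log units; beyond the scatter) that this estimate implies is expected to be modest and toward stronger inhibition, though a limit rather than a number remains quite possible.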

Compound 4, half-maximal inhibitory concentration: > 100000 nM
Compound 4: a limit, no number (the forecaster's own chance of this, stated with the estimate: 25%); middle value at least 2.8-fold (0.45 log units) away from the limit.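

Compound 4 gives > 100000 nM, which is a limit and not a number. In this assay, putting 4-chlorophenyl in place of 3-methoxyphenyl on the amide-type nitrogen gives an at least 1.4-fold higher number from compound 2 to compound 4 (0.14 log units; that floor lies within the scatter), so this swap brings no visible gain in inhibition, yet the floor of the step is too small to count as a proven loss. Among these compounds, this position, whose ring had so far separated compound 2 from compound 3 by more than the usual scatter, now also holds a second aryl group that leaves the read-out without a number: the limit of > 100000 nM in this assay, at which 2 of the 4 values shown sit.

As far as these compounds go, how far compound 4 truly lies from compound 2 remains unknown, and so does whether the change of substituent or its place on the ring matters more, a question that a 4-methoxyphenyl or a 3-chlorophenyl group on this nitrogen would help to separate. Also open, from the compounds shown here alone, is what an amine or a carboxylic acid on this ring would do to the numbers in this assay.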